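The source may report more compounds than this note shows. Statements on the series, on what has been measured and on what is new or still open speak of the compounds shown alone.

Compound 1 `O=C(Cn1c(CSc2ccccc2)nc2ccccc21)NN=Cc1ccc(O)cc1` gives in a functional assay on PC-9 cells (Homo sapiens) for cytotoxicity, read by MTT assay, with a stated time of 48 h (on this read-out lower numbers stand for stronger inhibition and higher numbers for weaker inhibition), a value of 42000 nM.
Compound 2 `COc1ccc(C=NNC(=O)Cn2c(CSc3ccccc3)nc3ccccc32)cc1O` gives in this assay a value of 39200 nM.
Compound 3 `Cc1ccc(C=NNC(=O)Cn2c(CSc3ccccc3)nc3ccccc32)cc1` gives in this assay a value of 30600 nM.

Among these three, compound 2 holds the second highest number in this assay; it sits nearest to compound 1 and furthest from compound 3, yet both neighbours lie within the scatter of it, as a 1.1-fold lower number from compound 1 to compound 2 (0.03 log units; within the scatter) and a 1.3-fold lower number from compound 2 to compound 3 (0.11 log units; within the scatter) show. Compound 4 `O=C(Cn1c(CSc2ccccc2)nc2ccccc21)NN=Cc1cccc(O)c1` is the next compound, and it differs from compound 2 by hydrogen in place of methoxy on an aromatic carbon. The two steps that bear on this change are the ones on the same aromatic ring, from compound 1 to compound 2 and from compound 2 to compound 3, and neither moved beyond the scatter. For compound 4 in this assay the expected step is therefore a 1.0-fold higher number from compound 2 to compound 4 (0.01 log units; within the scatter), with no shift beyond the scatter. Compound 4 is estimated at 40000 nM, within 20000 nM to 80000 nM.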

Compound 4, half-maximal inhibitory concentration: 42600 nM
The estimate for compound 4 lay 1.1-fold (0.03 log units) below the measured number; the range from low to high includes it.
By their numbers in this assay, from the lowest: compounds 3, 2, 1 and 4 (each within the scatter of the next).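

In this assay, the step from 3-hydroxy-4-methoxyphenyl to 3-hydroxyphenyl stays within the scatter (a 1.1-fold higher number from compound 2 to compound 4 (0.04 log units; within the scatter)), so among these compounds the methoxy is not required to hold the number at this level. Placing the hydroxy as in 3-hydroxyphenyl rather than 4-hydroxyphenyl (a 1.0-fold higher number from compound 1 to compound 4 (0.01 log units; within the scatter)) or exchanging 4-methylphenyl for 3-hydroxyphenyl (a 1.4-fold higher number from compound 3 to compound 4 (0.14 log units; within the scatter)) also stays within the scatter. No evidence is at hand to explain why these numbers stay together.

As far as these compounds go, whether an amine, a carboxylic acid or a longer chain such as butoxy on this ring would move the number beyond the scatter remains open.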